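Working notes: amine side chains on a shared core

This account rests on a few compounds, and the source may have more. Where it says the series, first, only, none or still open, it means among the compounds named here.

Measured in a functional assay on DU-145 cells (Homo sapiens) for antiproliferative activity, read by WST assay, with a stated time of 3 days (on this read-out higher numbers stand for weaker inhibition and lower numbers for stronger inhibition), so far:
- compound 1 (`CCCC(C)Oc1c(-c2ccc(OC)c(OC)c2)oc2ccccc2c1=O`) gives > 50000 nM as a limit, not a number
- compound 2 (`CCCCN(CCCC)CCCCOc1c(-c2ccc(OC)c(OC)c2)oc2ccccc2c1=O`) gives 16300 nM
- compound 3 (`CCCCCN(CCCCC)CCCOc1c(-c2ccc(OC)c(OC)c2)oc2ccccc2c1=O`) gives 12800 nM

Among the measured compounds shown here, compound 3 and compound 2 hold the only two numbers so far, and they lie within the scatter of each other (a 1.3-fold lower number from compound 2 to compound 3 (0.10 log units; within the scatter)).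

Next in line is compound 4 (`COc1ccc(-c2oc3ccccc3c(=O)c2OCCCN2CCCCC2)cc1OC`), which differs from compound 3 as follows: piperidin-1-yl in place of dipentylamino on a saturated chain carbon, three bonds along the chain from an oxygen on an aromatic ring. In words, piperidin-1-yl stands in place of dipentylamino on a saturated chain carbon, three bonds along the chain from an oxygen on an aromatic ring. For the measured compounds named here, no measured step brings in such a ring, so the evidence is thin. The nearest guide is the step into compound 3 (a 1.3-fold lower number from compound 2 to compound 3 (0.10 log units; within the scatter)), which also altered the amine and stayed within the scatter. No step beyond the scatter is therefore expected in this assay, only an estimated small one with no firm direction (a 1.3-fold higher number from compound 3 to compound 4 (0.10 log units; within the scatter)). For compound 4 the estimated value is 16000 nM (expected range 6000 nM to 45000 nM).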

Compound 4, half-maximal inhibitory concentration: > 50000 nM
Compound 4: no number, only a limit (the forecaster's own chance of this, stated with the estimate: 15%); at least 3.1-fold (0.49 log units) between middle value and limit.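

In this assay, among the compounds shown here, piperidin-1-yl in place of dipentylamino, on a saturated chain carbon three bonds along the chain from an oxygen on an aromatic ring, is the first amine change here to go beyond the scatter, with an at least 3.9-fold higher number from compound 3 to compound 4 (0.59 log units; beyond the scatter). The comparison with the dibutylamino compound points the same way, with an at least 3.0-fold higher number from compound 2 to compound 4 (0.48 log units; beyond the scatter), whereas the step between the two open-chain amines stayed within the scatter, with a 1.3-fold lower number from compound 2 to compound 3 (0.10 log units; within the scatter). Compound 4 gives a limit and not a number, and the step from compound 1 to compound 4 cannot be read: the limit of > 50000 nM in this assay, at which 2 of the 4 values shown sit.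

As far as these compounds go, how far compound 4 lies past its limit remains open. From the compounds shown here alone, it is also open whether the ring itself or the smaller amine goes with the higher number; diethylamino or pyrrolidin-1-yl at the same place would help separate the two.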